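Swapping hexyl for 4-nitrobenzyl on a shared core

The source may hold more compounds than are shown below. What is called first, only, known or untested is meant among the compounds shown, and "the series" means these compounds.

Compound 1 `COc1ccc(Cn2c(=O)n(C3OC(CO)[C@@H](O)[C@H]3O)c3nc(N)nc(O)c32)cc1` gives 2 uM
Compound 2 `CCCCCCn1c(=O)n(C2OC(CO)[C@@H](O)[C@H]2O)c2nc(N)nc(O)c21` gives 600 uM

Both numbers come from a functional assay with Mus musculus as the target (a higher number here means that more compound is needed for the effect, a lower number that less compound is needed), and compound 2 has the higher of the two. Compound 3 `Nc1nc(O)c2c(n1)n(C1OC(CO)[C@@H](O)[C@H]1O)c(=O)n2Cc1ccc([N+](=O)[O-])cc1` has not yet been measured. It carries 4-nitrophenyl in place of pentyl on a saturated chain carbon bound to an aromatic nitrogen, so it regains an aromatic ring where compound 1 has 4-methoxyphenyl. Among the compounds with values here, only one measured step bears on this: a 300-fold higher number from compound 1 to compound 2 (2.48 log units; beyond the scatter) for the reverse kind of change, pentyl in place of 4-methoxyphenyl. Going by these compounds, that step was large, so a large step towards a lower number is expected, although 4-nitrophenyl itself is untested and may not match 4-methoxyphenyl. The expected change is a 75-fold lower number from compound 2 to compound 3 (1.88 log units; beyond the scatter) as a rough estimate. Estimated for compound 3 is 8 uM as the middle value, with 1 uM to 100 uM as the expected range.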

Compound 3, concentration for half-maximal effect: 50 uM
Estimate against measurement, compound 3: 6.3-fold (0.80 log units) below; the range from low to high includes it.
By their numbers in this assay, from the lowest: compound 1; then compound 3; then compound 2.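

In this assay, 4-nitrobenzyl in place of hexyl gives a 12-fold lower number from compound 2 to compound 3 (1.08 log units; beyond the scatter), so at this position an aromatic ring carrying a nitro group is favoured over the hexyl chain, though this rests on a single pair of compounds. The ring alone does not settle the outcome, however: nitro in place of methoxy on an aromatic carbon gives a 25-fold higher number from compound 1 to compound 3 (1.40 log units; beyond the scatter), which shows that the group carried on the ring also matters greatly. No measurement is available that would explain either step.

The compounds shown leave open how a plain benzyl group, with nothing further on its ring, or a 4-aminobenzyl group would compare in this assay. They also leave open whether a longer chain than hexyl, or a chain ending in a carboxylic acid, would differ from compound 2.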